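This account rests on a few compounds, and the source may have more. Where it says the series, first, only, none or still open, it means among the compounds named here.

In an ADME assay on RAW264.7 cells (Mus musculus) for cytotoxicity, read by MTT assay, with a stated time of 48 h (on this read-out higher numbers stand for weaker inhibition and lower numbers for stronger inhibition), the measured compounds read as follows.
Compound 1 `CS(=O)(=O)Nc1ccc(NC(=O)c2ccc(Cl)cc2)cc1Cl` gives 79900 nM.
Compound 2 `CS(=O)(=O)Nc1ccc(NC(=O)c2ccc(C#N)cc2)cc1Cl` reaches only a limit of the assay, > 250000 nM.
Compound 3 `O=C(Nc1ccc(NS(=O)(=O)C(F)(F)F)c(F)c1)c1ccc(Cl)cc1` gives 3270 nM.

Compound 1 and compound 2 share a core and differ in one place: cyano in place of chloro on an aromatic carbon. In this assay that change produced an at least 3.1-fold higher number from compound 1 to compound 2 (0.49 log units; beyond the scatter), a step whose far end is set by the limit of > 250000 nM in this assay, at which 1 of the 3 values shown sits, so only its smallest possible size is known. Compound 3 stands on a different core; how its core differs from that of compound 1 is not broken down here. Among the numbers given in this assay, compound 3 holds the lowest, and compound 1 sits well beyond the scatter above it.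

Compound 4 `N#Cc1ccc(C(=O)Nc2ccc(NS(=O)(=O)C(F)(F)F)c(F)c2)cc1` has not yet been measured. Within the data shown here, it differs from compound 3 by cyano in place of chloro on an aromatic carbon, the same change, at the same place, as the one that separates compound 1 from compound 2. On that ground the step is expected to run in the same direction, towards a higher number, and to be at least of comparable size; in this assay the expected step is a 4.0-fold higher number from compound 3 to compound 4 (0.60 log units; beyond the scatter), set beside an at least 3.1-fold higher number from compound 1 to compound 2 (0.49 log units; beyond the scatter). Because compound 3 starts from 3270 nM, a number well inside the range the assay can read, compound 4 is expected to give a readable number as well. Compound 4 is thus estimated at 13000 nM, with a likely range from 4000 nM to 60000 nM.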

Compound 4, half-maximal inhibitory concentration: > 250000 nM
Compound 4 was reported as a limit; the forecaster's own chance of this, stated with the estimate: 5%; middle value at least 19-fold (1.28 log units) away from the limit.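

In this assay, cyano in place of chloro on an aromatic carbon again went with a higher number, here an at least 76-fold higher number from compound 3 to compound 4 (1.88 log units; beyond the scatter), so the direction of the change held on both cores shown: the same change on two cores in this assay, an at least 3.1-fold higher number (0.49 log units; beyond the scatter) from compound 1 to compound 2 and an at least 76-fold higher number (1.88 log units; beyond the scatter) from compound 3 to compound 4; the limit leaves it open whether they differ

Both steps end at a limit of the assay and not at a number, so each is known only by its smallest possible size, and the data do not show that the change counts for more on one core than on the other: the limit of > 250000 nM in this assay, at which 2 of the 4 values shown sit.

As far as these compounds go, the two pairs agree in direction and neither goes against the other, but two pairs do not make a rule for the series, and the true size of the change on either core remains unknown.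

The compounds shown leave open whether other groups in that place on the ring, such as an amine, a carboxylic acid or a longer chain, would move the number the same way as cyano does. Also open, from the compounds shown here alone, is how large the step from chloro to cyano really is, which only a pair with both values inside the readable range of the assay could tell.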